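One Ester Added to the Hydroxy Group of Compound 1

The source may report more compounds than this note shows. Statements on the series, on what has been measured and on what is new or still open speak of the compounds shown alone.

Compound 1: `C=C1CC[C@@H]2CC[C@H](OC(=O)C/C(C)=C/[C@@H](O)C1)C(=O)C2(C)C` — > 20 ug/mL
Compound 2: `C=C1CC[C@@H]2CCC3=C(C2(C)C)[C@@](OC)(C/C(C)=C/[C@@H](O)C1)OC3=O` — > 20 ug/mL
Compound 3: `C=C1CC[C@@H]2CCC3=C(C(=O)[C@@H](/C(C)=C/[C@@H](OC(C)=O)C1)[C@H]3O)C2(C)C` — > 20 ug/mL

Of the compounds shown here, three have been tested in a functional assay on WiDr cells (Homo sapiens) for cytotoxicity, read by MTT assay (a lower number here means a stronger inhibitor, a higher number a weaker inhibitor), and none of them gave a number. For compound 1 the value is a limit of the assay, not a measurement. For compound 2 the value is likewise a limit. For compound 3 the value is a limit as well. Compound 1 therefore stands level with the other two at the edge of what the assay can report: the limit of > 20 ug/mL in this assay, at which 3 of the 3 values shown sit. Going by the values given here, no pair of measured compounds differs in a single place, so no measured step is available to guide an expectation.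

Compound 4, `C=C1CC[C@@H]2CC[C@H](OC(=O)C/C(C)=C/[C@@H](OC(=O)c3ccc(Cl)cc3)C1)C(=O)C2(C)C`, differs from compound 1 in one place: (4-chlorophenyl)carbonyl in place of hydrogen on an oxygen on a saturated carbon. Among the compounds with values here, with no measured step to lean on, the expected step of an at least 1.3-fold lower number from compound 1 to compound 4 (0.12 log units; that floor lies within the scatter) is set small and of uncertain direction, with a good chance that compound 4 again stops at the limit. Compound 4 is estimated at 15 ug/mL, within a range from 4 ug/mL to 40 ug/mL.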

Compound 4, half-maximal inhibitory concentration: > 20 ug/mL
Compound 4 ended at the assay's limit (the forecaster's own chance of this, stated with the estimate: 55%); middle value at least 1.3-fold (0.12 log units) away from the limit.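

Compound 1 and compound 4 both stop at a limit of this assay, so no step can be read between them: the limit of > 20 ug/mL in this assay, at which 4 of the 4 values shown sit.

The compounds shown leave open whether (4-chlorophenyl)carbonyl in place of hydrogen changes the cytotoxicity of compound 1 at all.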